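Adding Chlorine and Methyl to the Pyridine Ring

A few compounds are considered here, and "the series" means these few. Any claim that something is new, unique, unknown or untested is made for them only; others in the source may bear on it.

Compound 3 `Cn1c(COc2cccc(C(=O)O)c2)nc2ccc(Oc3ncccc3F)cc21` gives 0.6 in a physicochemical assay for lipophilicity, read by LC-MS, in phosphate buffer, measured as octanol-water partition, with a stated time of 30 min, at pH 7.4, tested at 200 mM (on this read-out higher numbers stand for higher lipophilicity and lower numbers for lower lipophilicity), the second highest of three numbers: compound 1 `Cn1c(COc2cccc(C(=O)O)c2)nc2ccc(Oc3ccccn3)cc21` gives 0.4 and compound 2 `Cc1ccnc(Oc2ccc3nc(COc4cccc(C(=O)O)c4)n(C)c3c2)c1` gives 0.8, both within the scatter of compound 3. Compound 4 `Cc1cc(Cl)cnc1Oc1ccc2nc(COc3cccc(C(=O)O)c3)n(C)c2c1` carries 5-chloro-3-methylpyridin-2-yl in place of 3-fluoropyridin-2-yl on an oxygen on an aromatic ring. The measured steps offer a guide: a number 0.40 log units higher from compound 1 to compound 2 (beyond the scatter), and a number 0.20 log units higher from compound 1 to compound 3 (within the scatter), while a number 0.20 log units lower from compound 2 to compound 3 (within the scatter). Adding a methyl once moved the number beyond the scatter; compound 4 adds a methyl and also exchanges fluorine for chlorine, so a rise beyond the scatter in this assay is expected. The estimate for compound 4 is 1.5, between 0.9 and 2.1. This corresponds to an expected step of a number 0.90 log units higher from compound 3 to compound 4 (beyond the scatter).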

Compound 4, distribution coefficient: 1.8
Beside the measured number, compound 4's estimate is 0.30 log units below it; measured number inside the range.
By their numbers in this assay, from the lowest: compounds 1, 3 and 2 (each within the scatter of the next, the first and the last beyond it); then compound 4.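

Within the data shown here, the 5-chloro-3-methylpyridin-2-yl group brings much larger steps in this assay than any seen among the earlier compounds: a number 1.20 log units higher from compound 3 to compound 4 (beyond the scatter), and a number 1.40 log units higher from compound 1 to compound 4 (beyond the scatter). Even starting from a ring that already carries a methyl, there is a number 1.00 log units higher from compound 2 to compound 4 (beyond the scatter), so this position on the oxygen can span a far wider range than the earlier compounds showed. No measurement here explains the size of these steps. As far as these compounds go, the chlorine and the methyl arrive together, and their separate shares remain unknown. From the compounds shown here alone, how an amine or a methoxy group on this ring would read also stays open.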